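The source may report more compounds than this note shows. Statements on the series, on what has been measured and on what is new or still open speak of the compounds shown alone.

Compound 1 `CCCCCCCCCCc1cn(C[C@H](O)[C@H]2OC(=O)C(OCc3ccccc3)=C2OCc2ccccc2)nn1` stands second highest of the three numbers in a functional assay on HepG2 cells (Homo sapiens) for antiproliferative activity, read by MTT assay, with a stated time of 72 h (a higher number here means a weaker inhibitor, a lower number a stronger inhibitor), where compound 1 gives 12200 nM. Compound 2 `CC(C)(C)c1cn(C[C@H](O)[C@H]2OC(=O)C(OCc3ccccc3)=C2OCc2ccccc2)nn1` gives 29200 nM and compound 3 `O=C1O[C@H]([C@@H](O)Cn2cc(-c3cc(F)cc(F)c3)nn2)C(OCc2ccccc2)=C1OCc1ccccc1` gives 11600 nM in this assay. The change to compound 4 `O=C1O[C@H]([C@@H](O)Cn2cc(CNS(=O)(=O)c3ccc(Cl)cc3F)nn2)C(OCc2ccccc2)=C1OCc1ccccc1` is ((4-chloro-2-fluorophenyl)sulfonyl)amino in place of nonyl on a saturated chain carbon bound to an aromatic carbon. Within the data shown here, no measured step makes this exact exchange; the nearest are a 2.4-fold higher number from compound 1 to compound 2 (0.38 log units; beyond the scatter) and a 1.1-fold lower number from compound 1 to compound 3 (0.02 log units; within the scatter), both at the same aromatic carbon, which show that swapping the group there moves the number by a modest amount at most. Compound 4 is therefore expected to sit close to compound 1, with a step of a 1.2-fold higher number from compound 1 to compound 4 (0.09 log units; within the scatter) in this assay. The estimate for compound 4 is 15000 nM, with a range from 6000 nM to 40000 nM.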

Compound 4, half-maximal inhibitory concentration: 25500 nM
Estimate against measurement, compound 4: 1.7-fold (0.23 log units) below; the measured number falls inside the stated range.
By their numbers in this assay, from the lowest: compounds 3 and 1 (each within the scatter of the next); then compounds 4 and 2 (each within the scatter of the next).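

Replacing nonyl with ((4-chloro-2-fluorophenyl)sulfonyl)amino gives a 2.1-fold higher number from compound 1 to compound 4 (0.32 log units; beyond the scatter). This group differs far more from the chain it replaces than the earlier swaps did, adding a hydrogen-bond donor and hydrogen-bond acceptors, yet the number moves only modestly. Nothing available here explains the step. Going by these compounds, whether the sulfonyl, the amino hydrogen or the halogenated ring drives the change remains open. A simple amine or carboxylic acid on the same saturated chain carbon would test how much change this place accepts.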